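Hydrazone aryl swap in the triazole-pyridine ether series

The source may hold more compounds than are shown below. What is called first, only, known or untested is meant among the compounds shown, and "the series" means these compounds.

Measured in a functional assay on A549 cells (Homo sapiens) for cytotoxicity, read by MTT assay, with a stated time of 72 h; a higher number here means a weaker inhibitor, a lower number a stronger inhibitor:
compound 1 `CN(C)CCn1cnnc1-c1cc(Oc2ccc(NC(=O)N/N=C/c3cccc(Cl)c3Cl)cc2F)ccn1`: 1090 nM
compound 2 `CN(C)CCn1cnnc1-c1cc(Oc2ccc(NC(=O)N/N=C/c3cc(Br)c(O)c(Br)c3)cc2F)ccn1`: a limit only, > 100000 nM
compound 3 `CN(C)CCn1cnnc1-c1cc(Oc2ccc(NC(=O)N/N=C/c3ccc(O)c(F)c3)cc2F)ccn1`: 13400 nM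

Compound 3 holds the highest numbered value of the two plain numbers; compound 1 sits below it by a 12-fold higher number from compound 1 to compound 3 (1.09 log units; beyond the scatter), and compound 2 gives only a limit (the limit of > 100000 nM in this assay, at which 1 of the 3 values shown sits). The pairing with compound 2 is an at least 7.4-fold lower number from compound 2 to compound 3 (0.87 log units; beyond the scatter).

Compound 4 `CN(C)CCn1cnnc1-c1cc(Oc2ccc(NC(=O)N/N=C/c3ccc(F)cc3Cl)cc2F)ccn1` differs from compound 3 by 2-chloro-4-fluorophenyl in place of 3-fluoro-4-hydroxyphenyl on a carbon with a double bond to nitrogen. The nearest measured guide is the reverse-direction step between compound 1 and compound 3, which was a 12-fold higher number from compound 1 to compound 3 (1.09 log units; beyond the scatter); compound 4 carries two halogens and no hydroxyl, as compound 1 does. A lower number of comparable size is therefore expected, an 8.9-fold lower number from compound 3 to compound 4 (0.95 log units; beyond the scatter). Compound 4 is estimated at 1500 nM, within 500 nM to 5000 nM.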

Compound 4, half-maximal inhibitory concentration: 1120 nM
Compound 4: the middle estimate sits 1.3-fold (0.13 log units) above what was measured, within the range that was stated.
By their numbers in this assay, from the lowest: compounds 1 and 4 (each within the scatter of the next); then compound 3. At a limit, above all of these: compound 2.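

On the carbon with a double bond to nitrogen, two different halogen patterns read alike (a 1.0-fold higher number from compound 1 to compound 4 (0.01 log units; within the scatter)), so the 2,3-dichlorophenyl result is no longer a lone case. The two compounds without a hydroxyl separate from both hydroxyl-bearing compounds (a 12-fold lower number from compound 3 to compound 4 (1.08 log units; beyond the scatter); an at least 89-fold lower number from compound 2 to compound 4 (1.95 log units; beyond the scatter)), and no compound shown goes against this split. The value for compound 2 is a limit, not a number: the limit of > 100000 nM in this assay, at which 1 of the 4 values shown sits.

From the compounds shown here alone, whether the split follows the hydroxyl or the halogens stays open, as each step changes both. A plain phenyl, a methoxyphenyl or an aminophenyl on this carbon would separate the two.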